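Azetidine oxadiazole series: piperidine urea to oxolane amide

A few compounds are considered here, and "the series" means these few. Any claim that something is new, unique, unknown or untested is made for them only; others in the source may bear on it.

Measured so far in an assay on HEK293 cells for positive allosteric modulation of metabotropic glutamate receptor 5 (Homo sapiens), read by FLIPR; a higher number here means that more compound is needed for the effect, a lower number that less compound is needed:
- compound 1 `O=C(N1CCC(F)CC1)N1CC(c2nc(-c3cccc(Cl)c3)no2)C1`: 990 nM
- compound 2 `O=C(N1CCCCC1)N1CC(c2nc(-c3cccc(Cl)c3)no2)C1`: 370 nM

Compound 2 gives the lowest of the two numbers, with compound 1 next; the step of a 2.7-fold lower number from compound 1 to compound 2 (0.43 log units; beyond the scatter) covers hydrogen in place of fluoro on a saturated ring carbon. Compound 3 `O=C(C1CCCO1)N1CC(c2nc(-c3cccc(Cl)c3)no2)C1` differs from compound 2 by oxolan-2-yl in place of piperidin-1-yl on a carbonyl carbon. Within the data shown here, no measured step touches the carbonyl substituent, so the only change seen so far bears on a different position and gives no direction here. The number expected for compound 3 is therefore near that of compound 2, with wide uncertainty: 600 nM (range 150 nM to 2500 nM), a step of a 1.6-fold higher number from compound 2 to compound 3 (0.21 log units; within the scatter) in this assay.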

Compound 3, half-maximal effective concentration: > 10000 nM
Compound 3: no number, only a limit; the forecaster's own chance of this, stated with the estimate: 10%; middle value at least 16-fold (1.22 log units) away from the limit.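

The carbonyl substituent proves far less tolerant than the saturated ring carbon probed earlier: oxolan-2-yl in place of piperidin-1-yl gives an at least 27-fold higher number from compound 2 to compound 3 (1.43 log units; beyond the scatter). Against the fluorinated piperidine, the same position gives an at least 10-fold higher number from compound 1 to compound 3 (1.00 log units; beyond the scatter). Compound 3 reads > 10000 nM, which is a limit of the assay and not a number.

This single change alters ring size, ring hetero atom and the atom bonded to the carbonyl carbon together, so their shares cannot be separated. Going by these compounds, whether pyrrolidin-1-yl or morpholin-4-yl on the carbonyl carbon would stay near compound 2 remains open.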